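A few compounds are considered here, and "the series" means these few. Any claim that something is new, unique, unknown or untested is made for them only; others in the source may bear on it.

Compound 1 `O=C(CN1CCN(C(=O)c2cccc(Cl)c2)CC1)N1CCN(CCCc2c[nH]c3ccccc23)CC1` and compound 3 `O=C(CN1CCN(C(=O)c2ccc(Cl)cc2)CC1)N1CCN(CCCc2c[nH]c3ccc(F)cc23)CC1` carry the same kind of substituted benzoyl piperazine; the difference between the two cores is not broken down here. In an ADME assay on SH-SY5Y cells (Homo sapiens) for cytotoxicity, read by MTT assay, with a stated time of 72 h (on this read-out lower numbers stand for stronger inhibition and higher numbers for weaker inhibition), compound 1 gives 120000 nM and compound 3 gives 125000 nM. Compound 2 `COc1cccc(C(=O)N2CCN(CC(=O)N3CCN(CCCc4c[nH]c5ccccc45)CC3)CC2)c1` is the methoxy analogue of compound 1 (methoxy in place of chloro on an aromatic carbon). In this assay compound 2 gives > 200000 nM, which is a limit of the assay rather than a number (the limit of > 200000 nM in this assay, at which 1 of the 3 values shown sits). That gives an at least 1.6-fold higher number from compound 1 to compound 2 (0.22 log units; that floor lies within the scatter). Compound 4 `COc1ccc(C(=O)N2CCN(CC(=O)N3CCN(CCCc4c[nH]c5ccc(F)cc45)CC3)CC2)cc1` stands to compound 3 as compound 2 stands to compound 1 (methoxy in place of chloro on an aromatic carbon); it is the same kind of change, differing in its place, para to a large group rather than meta to a large group. From compound 3 to compound 4 a step of a 2.0-fold higher number from compound 3 to compound 4 (0.30 log units; within the scatter) is expected in this assay, resting on compound 1 and the step of an at least 1.6-fold higher number from compound 1 to compound 2 (0.22 log units; that floor lies within the scatter). Compound 4 is estimated at 250000 nM, between 110000 nM and 600000 nM.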

Compound 4, half-maximal inhibitory concentration: 161000 nM
The estimate for compound 4 lay 1.6-fold (0.19 log units) above the measured number; measured number inside the range.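

Methoxy in place of chloro gives a 1.3-fold higher number from compound 3 to compound 4 (0.11 log units; within the scatter) in this assay, so on this core the change shows no step beyond the scatter. Compound 2 gives > 200000 nM, which is a limit of the assay and not a number. The two steps therefore cannot be sized against each other, and the pairs show neither that the change carries over with a fixed size nor that its size depends on the core: the same change on two cores in this assay, an at least 1.6-fold higher number (0.22 log units; that floor lies within the scatter) from compound 1 to compound 2 and a 1.3-fold higher number (0.11 log units; within the scatter) from compound 3 to compound 4; the limit leaves it open whether they differ

The two pairs also differ in where the change sits on the aromatic ring, so the effects of core and place are not separated here. On these data alone, whether an amine or a carboxylic acid in place of chloro would give a step beyond the scatter stays open.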